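The source may hold more compounds than are shown below. What is called first, only, known or untested is meant among the compounds shown, and "the series" means these compounds.

Compound 1 `Cc1ccc2nc([C@H](CC(C)C)N3C(=O)CN(c4ccc(Oc5ccccc5)cc4)C3=O)n(C)c2c1` gives 65600 nM in an assay on isolated protein for inhibition of Bile acid receptor (Homo sapiens), read by TR-FRET and LanthaScreen; on this read-out higher numbers stand for weaker inhibition and lower numbers for stronger inhibition. Compound 2 `CC(C)C[C@@H](c1nc2ccc(C(=O)O)cc2n1C)N1C(=O)CN(c2ccc(Oc3ccccc3)cc2)C1=O` gives 43400 nM in this assay, and compound 3 `CC(C)C[C@@H](c1nc2ccc(C(=O)O)cc2n1C)N1C(=O)N(c2ccc(Oc3ccccc3)cc2)C(C)(C)C1=O` gives 105000 nM. Compound 2 has the lowest number of the three; compound 1 stands within the scatter of it, while compound 3 stands beyond it. Among the compounds with values here, the only measured step, a 1.5-fold lower number from compound 1 to compound 2 (0.18 log units; within the scatter), concerns a substituent on an aromatic carbon. Compound 4 `Cn1c([C@H](CC2CCCCC2)N2C(=O)CN(c3ccc(Oc4ccccc4)cc3)C2=O)nc2ccc(C(=O)O)cc21` carries cyclohexyl in place of isopropyl on a saturated chain carbon, two bonds along the chain from an amide-type nitrogen in a ring and an aromatic carbon. Within the data shown here, no measured step covers this change: the step from compound 1 to compound 2 alters another place, and compound 2 and compound 3 differ at yet another site. The expected step is therefore a 1.1-fold lower number from compound 2 to compound 4 (0.04 log units; within the scatter), with no clear direction beyond the scatter. Compound 4 is estimated at 40000 nM, within a range from 13000 nM to 120000 nM.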

Compound 4, half-maximal inhibitory concentration: 24400 nM
Compound 4: middle estimate off by 1.6-fold (0.21 log units), on the high side, within the range that was stated.
By their numbers in this assay, from the lowest: compounds 4, 2, 1 and 3 (each within the scatter of the next, the first and the last beyond it).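

In this assay, within the data shown here, cyclohexyl in place of isopropyl at this saturated chain carbon gives a 1.8-fold lower number from compound 2 to compound 4 (0.25 log units; within the scatter), the first reading at this position. A six-membered carbon ring is thus accepted here with the number staying within the scatter, so this change shows no clear gain or loss. No supporting data explain the size of this step.

Open, from the compounds shown here alone, is whether phenyl, an amine or a hydroxyl at this position would move the number beyond the scatter. Also open, going by these compounds, is whether cyclohexyl would give a similar step on the core of compound 3.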